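The source may report more compounds than this note shows. Statements on the series, on what has been measured and on what is new or still open speak of the compounds shown alone.

Compound 1 `C=CCOc1ccccc1Cc1cnc(N)nc1N` and compound 2 `NC(=O)COc1ccccc1Cc1cnc(N)nc1N` share one core and differ only in the group carried on the saturated chain carbon bound to an oxygen on an aromatic ring. In an assay for inhibition of Dihydrofolate reductase (Gallus gallus) (a lower number here means a stronger inhibitor, a higher number a weaker inhibitor), compound 1 gives 21400 nM. In this assay compound 2 gives 33900 nM. The step of a 1.6-fold higher number from compound 1 to compound 2 (0.20 log units; within the scatter) lies within the scatter, so these two numbers cannot be told apart. Among the measured compounds shown here, compound 2 therefore carries the higher of the two numbers measured so far, with compound 1 as its only neighbour and a gap that means nothing beyond the scatter.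

Compound 3 `Nc1ncc(Cc2ccccc2OCc2ccccc2)c(N)n1` keeps the same core and differs from compound 2 by phenyl in place of carbamoyl on a saturated chain carbon bound to an oxygen on an aromatic ring. For the measured compounds named here, the only measured step that bears on this change is the one from compound 1 to compound 2, which swapped one small group for another at the same place and stayed within the scatter. The entering phenyl is a different kind of group, an aromatic ring, so the earlier step gives little guidance; a modest move toward a lower number, a 2.8-fold lower number from compound 2 to compound 3 (0.45 log units; beyond the scatter), is expected, with low confidence. For compound 3 the estimate in this assay is 12000 nM, within a range from 3000 nM to 45000 nM.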

Compound 3, inhibition constant: 9120 nM
The estimate for compound 3 lay 1.3-fold (0.12 log units) above the measured number; measured number inside the range.
By their numbers in this assay, from the lowest: compound 3; then compounds 1 and 2 (each within the scatter of the next).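

On a saturated chain carbon bound to an oxygen on an aromatic ring, the earlier swap of vinyl for carbamoyl produced no change that could be read, but phenyl does move the number in this assay: there is a 3.7-fold lower number from compound 2 to compound 3 (0.57 log units; beyond the scatter) with phenyl in place of carbamoyl, and a 2.3-fold lower number from compound 1 to compound 3 (0.37 log units; beyond the scatter) with phenyl in place of vinyl. Both steps are modest and point the same way, so this position does respond to the group it carries, and among the three compounds shown, the one with phenyl has the lowest number, while the vinyl and carbamoyl compounds cannot be told apart. Nothing available explains this shift.

Phenyl differs from the two other groups both in having a ring and in its count of heavy atoms, so these three compounds cannot show which of the two matters. A saturated ring such as cyclohexyl would help to separate them, while a longer chain carrying the phenyl, or a phenyl bearing a chlorine, would show how far the trend extends.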